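Swapping a chlorophenyl for a chloropyridinyl on the amide

The source may report more compounds than this note shows. Statements on the series, on what has been measured and on what is new or still open speak of the compounds shown alone.

Measured so far:
- compound 1 `Cc1noc(C)c1-c1cnc(N)c(Oc2ccc(C(=O)Nc3ccccc3Cl)cc2)n1`: 81300 nM
- compound 2 `Cc1noc(C)c1-c1cnc(N)c(Oc2ccc(C(=O)Nc3cccc(Cl)c3)cc2)n1`: 1340 nM
- compound 3 `Cn1cc(-c2cnc(N)c(Oc3ccc(C(=O)Nc4ccccc4Cl)cc3)n2)cn1`: 73000 nM

In a functional assay on HeLa cells (Homo sapiens) for inhibition, read by MTT assay, with a stated time of 72 h (on this read-out lower numbers stand for stronger inhibition and higher numbers for weaker inhibition), compound 3 gives 73000 nM, the second highest number of the three. Its nearest neighbour is compound 1, which in this assay gives 81300 nM; the two differ only in the ring attached to the shared core, and a 1.1-fold lower number from compound 1 to compound 3 (0.05 log units; within the scatter). The only large movement seen is a 61-fold lower number from compound 1 to compound 2 (1.78 log units; beyond the scatter), which came from moving the chlorine on the phenyl ring, not from changing the ring atoms themselves.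

Compound 4 `Cn1cc(-c2cnc(N)c(Oc3ccc(C(=O)Nc4cccc(Cl)n4)cc3)n2)cn1` is the unmeasured compound. The change from compound 3 is 6-chloropyridin-2-yl in place of 2-chlorophenyl on an amide-type nitrogen. Within the data shown here, no measured step tests this kind of swap: the step from compound 1 to compound 2 moves the chlorine but keeps a carbon ring, and the step from compound 1 to compound 3 touches a different part of the molecule. So there is no clear basis to expect a movement beyond the scatter in either direction in this assay.

Compound 4 is therefore expected to give about 60000 nM in this assay, within a broad range from 15000 nM to 200000 nM. This estimate corresponds to a 1.2-fold lower number from compound 3 to compound 4 (0.09 log units; within the scatter).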

Compound 4, half-maximal inhibitory concentration: 38200 nM
Estimate against measurement, compound 4: 1.6-fold (0.20 log units) above; the range from low to high includes it.
By their numbers in this assay, from the lowest: compound 2; then compounds 4, 3 and 1 (each within the scatter of the next, the first and the last beyond it).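

In this assay, placing 6-chloropyridin-2-yl instead of 2-chlorophenyl on the amide-type nitrogen gives a 1.9-fold lower number from compound 3 to compound 4 (0.28 log units; within the scatter). So at this place, a ring with 1 hydrogen-bond acceptor can replace a carbon-only ring with 0 without a change beyond the scatter, which the earlier compounds could not show, since their one step at this place, a 61-fold lower number from compound 1 to compound 2 (1.78 log units; beyond the scatter), only moved the chlorine on a carbon ring. No supporting measurement bears on this result.

The compounds shown leave open whether the same swap would be as quiet with 3,5-dimethyl-1,2-oxazol-4-yl on the shared core, or when set against 3-chlorophenyl rather than 2-chlorophenyl. They also leave open what the chlorine contributes, as a plain pyridin-2-yl or a methoxy group in its place would show.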